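Oxazole for thiazole on the fused core, sigma binding

The compounds below may be only part of what the source reports. "The series", "measured", "known", "first", "only" and "open" are said of these compounds alone.

Three analogues sharing one core have been measured in an assay on HEK293 cells for displacement of a labelled ligand from Sigma non-opioid intracellular receptor 1 (Homo sapiens), read by scintillation counting, with a stated time of 120 min; on this read-out lower numbers stand for stronger inhibition and higher numbers for weaker inhibition. Compound 1 `Cc1ccc(C)c(-c2ncnc3c2cnn3CCN2CCCCC2)c1` gives 63 nM. Compound 2 `Cc1cncc(-c2ncnc3c2cnn3CCN2CCCCC2)c1` gives 447 nM, and compound 3 `c1nc(-c2cnsc2)c2cnn(CCN3CCCCC3)c2n1` gives 475 nM. Compound 3 carries the highest number of the three, yet the step of a 1.1-fold higher number from compound 2 to compound 3 (0.03 log units; within the scatter) is within the scatter, so compounds 2 and 3 are not distinguished; compound 3 is set apart only from compound 1, by a 7.5-fold higher number from compound 1 to compound 3 (0.88 log units; beyond the scatter).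

Compound 4 `c1coc(-c2ncnc3c2cnn3CCN2CCCCC2)n1` differs from compound 3 by 1,3-oxazol-2-yl in place of 1,2-thiazol-4-yl on an aromatic carbon. Within the data shown here, the steps that bear on this are a 7.1-fold higher number from compound 1 to compound 2 (0.85 log units; beyond the scatter) and a 7.5-fold higher number from compound 1 to compound 3 (0.88 log units; beyond the scatter), both modest and both away from the 2,5-dimethylphenyl of compound 1, together with the flat step between compound 2 and compound 3. Exchanging one five-membered ring bearing two hetero atoms for another is therefore expected to give a 1.1-fold higher number from compound 3 to compound 4 (0.02 log units; within the scatter), i.e. nothing beyond the scatter. Compound 4 is estimated at 500 nM, with a range of 200 nM to 1300 nM.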

Compound 4, inhibition constant: 23800 nM
For compound 4 the middle estimate is 48-fold (1.68 log units) below the measured one; the measured number lies above the stated range.
By their numbers in this assay, from the lowest: compound 1; then compounds 2 and 3 (each within the scatter of the next); then compound 4.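

At this aromatic carbon, the flat step between compound 2 and compound 3 gave no sign of how much the choice of five-membered ring can matter: in this assay, two rings alike in heavy-atom, donor and acceptor counts are separated by a 50-fold higher number from compound 3 to compound 4 (1.70 log units; beyond the scatter). The 1,3-oxazol-2-yl group also stands well apart from the two other groups that are not five-membered oxazoles, as shown by a 53-fold higher number from compound 2 to compound 4 (1.73 log units; beyond the scatter) and by a 380-fold higher number from compound 1 to compound 4 (2.58 log units; beyond the scatter). No measurement at hand accounts for the size of these steps.

The change alters both the ring hetero atoms and the point of attachment, so the data do not say which of these carries the loss. A 1,3-thiazol-2-yl or a 1,2-oxazol-4-yl group at this carbon would separate the two.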